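Swapping trifluoromethyl for an aminopiperidinylmethyl group

A few compounds are considered here, and "the series" means these few. Any claim that something is new, unique, unknown or untested is made for them only; others in the source may bear on it.

Measured so far:
compound 1 `Cc1cn(-c2cc(CCS(N)(=O)=O)cc(NC(=O)c3ccc(C)c(Nc4nccc(-c5ccccc5)n4)c3)c2)cn1` — 58.5 ng.h/mL
compound 2 `Cc1cn(-c2cc(NC(=O)c3ccc(C)c(Oc4ccccc4)c3)cc(C(F)(F)F)c2)cn1` — 508 ng.h/mL

In an ADME assay on the whole organism (Mus musculus, strain CD1), read by LC-MS, using cassette dosing, with a stated time of 24 h, at a dose of 0.4 mg/kg by the intravenous route (a lower number here means less compound in the circulation, a higher number more compound in the circulation at the dose given), compound 2 gives 508 ng.h/mL, the higher of the two numbers, while compound 1 gives 58.5 ng.h/mL. Within the data shown here, no single-change step between the measured pair exists. Compound 3 `Cc1cn(-c2cc(CN3CCC[C@H](N)C3)cc(NC(=O)c3ccc(C)c(Oc4ccccc4)c3)c2)cn1` keeps the core of compound 2 but carries (3-aminopiperidin-1-yl)methyl in place of trifluoromethyl on an aromatic carbon. Because compound 2 stands at 508 ng.h/mL and compound 1 at 58.5 ng.h/mL, compound 3 is expected to land below compound 2, a step of a 3.4-fold lower number from compound 2 to compound 3 (0.53 log units; beyond the scatter), likely beyond the scatter. The estimate for compound 3 in this assay is 150 ng.h/mL, with a range from 40 ng.h/mL to 500 ng.h/mL.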

Compound 3, area under the concentration-time curve: 722 ng.h/mL
The estimate for compound 3 lay 4.8-fold (0.68 log units) below the measured number, and the stated range ends below it.
By their numbers in this assay, from the lowest: compound 1; then compounds 2 and 3 (each within the scatter of the next).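

With (3-aminopiperidin-1-yl)methyl in place of trifluoromethyl on this aromatic carbon, the pair shows a 1.4-fold higher number from compound 2 to compound 3 (0.15 log units; within the scatter) in this assay and so no change beyond the scatter. This position therefore takes the larger group, with its non-aromatic ring, amine and defined stereocentre, with the circulating amount staying within the scatter of compound 2. No evidence at hand bears on this result. From the compounds shown here alone, the opposite stereoisomer of the 3-aminopiperidine remains open. So does the outcome with a morpholine or a carboxylic acid at this position.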